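Sulfanyl chain change from compound 2 to compound 3

This account rests on a few compounds, and the source may have more. Where it says the series, first, only, none or still open, it means among the compounds named here.

Measured in a functional assay on HepG2 cells (Homo sapiens) for inhibition, read by MTT assay, with a stated time of 48 h; on this read-out higher numbers stand for weaker inhibition and lower numbers for stronger inhibition:
Compound 1 `CCSc1nnc(-c2cc(OC)c(OC)c(OC)c2)n1-c1ccc(N(C)C)cc1`: > 60000 nM, a limit.
Compound 2 `COc1cc(-c2nnc(SCc3ccc(C)cc3)n2-c2ccc(N(C)C)cc2)cc(OC)c1OC`: > 60000 nM, a limit.

Compound 2 therefore has no number, only a limit. The evidence so far is the limit of > 60000 nM in this assay, at which 2 of the 2 values shown sit. Compound 3 `COc1ccc(C(=O)CSc2nnc(-c3cc(OC)c(OC)c(OC)c3)n2-c2ccc(N(C)C)cc2)cc1` carries (4-methoxyphenyl)carbonyl in place of 4-methylphenyl on a saturated chain carbon bound to a sulfur, placing (4-methoxyphenyl)carbonyl where 4-methylphenyl stood on a saturated chain carbon bound to a sulfur. No size can be carried over from a step that the two limits leave unreadable from compound 1 to compound 2, so only a small strengthening is expected in this assay, and another limit is quite likely. The estimated change is an at least 1.3-fold lower number from compound 2 to compound 3 (0.12 log units; that floor lies within the scatter). For compound 3 the estimated value is 45000 nM, with an expected range of 8000 nM to 60000 nM.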

Compound 3, half-maximal inhibitory concentration: 18800 nM
Beside the measured number, compound 3's estimate is 2.4-fold (0.38 log units) above it; low and high end bracket the measured number.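

In this assay, this position on a saturated chain carbon bound to a sulfur now gives a readable change: (4-methoxyphenyl)carbonyl in place of 4-methylphenyl gives an at least 3.1-fold lower number from compound 2 to compound 3 (0.50 log units; beyond the scatter), and in place of methyl it gives an at least 3.1-fold lower number from compound 1 to compound 3 (0.50 log units; beyond the scatter). Both steps are floors, since compound 1 and compound 2 stand only as limits: the limit of > 60000 nM in this assay, at which 2 of the 3 values shown sit. The step from compound 1 to compound 2 cannot be read.

Going by these compounds, the carbonyl and the methoxy enter together, so which of them carries the step stays open. On these data alone, how an amine or a carboxylic acid would read at this position also stays open.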